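A few compounds are considered here, and "the series" means these few. Any claim that something is new, unique, unknown or untested is made for them only; others in the source may bear on it.

Series notes. The shared core of compound 1 `COC(=O)C1=C(C)N=C(C)/C(=C(\O)OC)C1c1ccccc1N` carries a 2-aminophenyl group on a saturated ring carbon. In a functional assay (muscle tissue) with Cavia porcellus as the target (a lower number here means that less compound is needed, a higher number that more compound is needed for the effect), compound 1 gives 39800 nM, the higher of the two numbers available. Compound 2 `COC(=O)C1=C(C)N=C(C)/C(=C(\O)OC)C1c1cc([N+](=O)[O-])ccc1O` carries a different aryl group at the same place; in this assay compound 2 gives 100 nM, a number far below that of compound 1 and beyond the scatter. For the measured compounds named here, no measured pair differs in only one place, so no single-change step is known.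

Compound 3 `COC(=O)C1=C(C)N=C(C)/C(=C(\O)OC)C1c1cc(C)ccc1C` is unmeasured. Against compound 1 the change is 2,5-dimethylphenyl in place of 2-aminophenyl on a saturated ring carbon. The two measured compounds show that the aryl group moves the number across a wide range, so a step beyond the scatter toward a lower number is expected for an 8.0-fold lower number from compound 1 to compound 3 (0.90 log units; beyond the scatter), though smaller than the gap to compound 2. Compound 3 is estimated at 5000 nM, within 800 nM to 30000 nM.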

Compound 3, half-maximal effective concentration: 100 nM
Compound 3: middle estimate off by 50-fold (1.70 log units), on the high side, outside the stated range (below it).
By their numbers in this assay, from the lowest: compounds 2 and 3 (each within the scatter of the next); then compound 1.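

In this assay, the aryl group on the saturated ring carbon now has a single-change step: 2,5-dimethylphenyl in place of 2-aminophenyl gives a 400-fold lower number from compound 1 to compound 3 (2.60 log units; beyond the scatter), so a change at this one place is enough to move the number by a large amount. The entering group has 0 hydrogen-bond donors and 0 hydrogen-bond acceptors, so neither is needed in this group to reach the value of compound 3 100 nM. Two different aryl groups reach the same range, as compound 2 gives 100 nM, within the scatter of compound 3. The data on hand give no explanation for the step.

The compounds shown leave open whether the step follows from losing the amine or from gaining the two methyl groups. A phenyl group with a single methyl, a methoxy or a chlorine would help to separate these two readings.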